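Hydroxy Entering a Chain Methyl: Expected Cytotoxicity

A few compounds are considered here, and "the series" means these few. Any claim that something is new, unique, unknown or untested is made for them only; others in the source may bear on it.

Two compounds of this series carry numbers. Compound 1 `CC1(C)O[C@@H]2CC[C@](C)(O)[C@H](CC[C@@]34O[C@]3(C)[C@H](O)CC3C(CC[C@@]3(C)O)C4(C)C)[C@@]2(C)CC[C@H]1O` in a functional assay on KB 3-1 cells (Homo sapiens) for cytotoxicity, read by MTT assay, with a stated time of 68 h, tested at 5 uM (on this read-out higher numbers stand for weaker inhibition and lower numbers for stronger inhibition), gives 8.6 nM. Compound 2 `CC1=CCC2C(CC[C@@]2(C)O)C(C)(C)C1CC[C@@H]1[C@@]2(C)CC[C@@H](O)C(C)(C)O[C@@H]2CC[C@]1(C)O` in this assay gives 5 nM, the lower of the two numbers, though compound 1 stands within the scatter of it. Compound 3 `CC1(C)C(CC[C@@H]2[C@@]3(C)CC[C@@H](O)C(C)(C)O[C@@H]3CC[C@]2(C)O)C(CO)=CCC2C1CC[C@@]2(C)O` is not yet measured. It differs from compound 2 by hydroxy in place of hydrogen on a saturated chain carbon bound to a double-bonded ring carbon; read one bond further out, methyl becomes hydroxymethyl. Within the data shown here, no measured pair shows such a change, so no step size can be drawn from the data. The step of a 1.4-fold higher number from compound 2 to compound 3 (0.15 log units; within the scatter) is expected to stay within the scatter, as nothing here argues for a larger shift. Compound 3 is therefore estimated at 7 nM, ranging from 2.5 nM to 20 nM.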

Compound 3, half-maximal inhibitory concentration: 5.9 nM
Compound 3: the middle estimate sits 1.2-fold (0.07 log units) above what was measured, and the stated range covers the measured number.
By their numbers in this assay, from the lowest: compounds 2, 3 and 1 (each within the scatter of the next).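

In this assay the methyl to hydroxymethyl change at this position gives a 1.2-fold higher number from compound 2 to compound 3 (0.07 log units; within the scatter) and no shift beyond the scatter, so this carbon accepts hydroxy in place of hydrogen without a measurable loss. Among these compounds, this is the only step read at this position, a saturated chain carbon bound to a double-bonded ring carbon. Nothing measured offers a reason for the flat step.

On these data alone, whether a carboxylic acid, an amine or a methyl ether at this carbon would hold the number stays open. One step also leaves open how the same change reads on the core of compound 1.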